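Trading Dichlorophenyl for Trifluoromethylphenyl on a Urea

The compounds below may be only part of what the source reports. "The series", "measured", "known", "first", "only" and "open" are said of these compounds alone.

Compound 1 `O=C(Nc1cccc(-n2cc(-c3ccncc3)c(-c3ccc(Cl)c(O)c3)n2)c1)Nc1ccc(Cl)c(Cl)c1` ends in a urea whose outer arm is a 3,4-dichlorophenyl group. In a functional assay on OVCAR-3 cells (Homo sapiens) for inhibition, read by sulforhodamine B assay, with a stated time of 48 h (a lower number here means that less compound is tolerated, a higher number that more compound is tolerated), compound 1 gives > 32500 nM, which is a limit of the assay rather than a measured number. Compound 2 `COc1cc(-c2nn(-c3cccc(NC(=O)Nc4ccc(Cl)c(C(F)(F)F)c4)c3)cc2-c2ccncc2)ccc1Cl` likewise reaches only a limit in this assay, namely > 32500 nM. Within the data shown here, compound 3 `COc1cc(-c2nn(-c3cccc(NC(=O)c4ccccc4)c3)cc2-c2ccncc2)ccc1Cl` is the one compound with a measured number, giving 95800 nM in this assay. Among the measured compounds shown here, the single measured step, a step that the limit leaves unreadable from compound 2 to compound 3, cannot be sized, because its starting point sits at the limit of > 32500 nM in this assay, at which 2 of the 3 values shown sit. For the measured compounds named here, no measured pair touches the change now in question.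

Compound 4 `O=C(Nc1cccc(-n2cc(-c3ccncc3)c(-c3ccc(Cl)c(O)c3)n2)c1)Nc1cccc(C(F)(F)F)c1` differs from compound 1 in one place: 3-(trifluoromethyl)phenyl in place of 3,4-dichlorophenyl on an amide-type nitrogen. All three values shown cluster at or around the limit, so nothing in the data points toward a change beyond the usual scatter for compound 4; the step from compound 1 to compound 4 is therefore expected to be about a step that the limit leaves unreadable from compound 1 to compound 4, essentially flat. On that basis compound 4 is estimated at 50000 nM in this assay, with a likely range from 20000 nM to 150000 nM, and a good chance that only a limit rather than a number is recorded.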

Compound 4, concentration lethal to 50% of the cells: > 32500 nM
Compound 4 gave a limit, no number; the forecaster's own chance of this, stated with the estimate: 65%; the middle value does not contradict the limit.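

No size can be read for the step from compound 1 to compound 4, because both results are limits of the assay and not numbers: the limit of > 32500 nM in this assay, at which 3 of the 4 values shown sit.

The compounds shown leave open whether, in this assay, swapping 3,4-dichlorophenyl for 3-(trifluoromethyl)phenyl on an amide-type nitrogen changes the result at all.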